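A few compounds are considered here, and "the series" means these few. Any claim that something is new, unique, unknown or untested is made for them only; others in the source may bear on it.

Measured compounds in an in vitro ADME assay on microsomes from liver (Mus musculus) for pharmacokinetics, read by LC-MS, with a stated time of 10 min, tested at 1 uM; on this read-out lower numbers stand for slow clearance and higher numbers for fast clearance:
compound 1, `Cc1cc(NC(=O)[C@H]2CN(C)C[C@@H]2c2ccc(/C=C/C(=O)Nc3ccccc3N)cc2)ccc1F`, gives 62 mL/min/kg
compound 2, `Cc1cc(NC(=O)[C@H]2CN(C)C[C@@H]2c2ccc(/C=C/C(=O)Nc3ccccc3N)cc2)ccc1Cl`, gives 65 mL/min/kg
compound 3, `CN1C[C@H](C(=O)Nc2ccc(F)cc2F)[C@@H](c2ccc(/C=C/C(=O)Nc3ccccc3N)cc2)C1`, gives 27 mL/min/kg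

Compound 1 and compound 2 differ in one place, (chloro in place of fluoro on an aromatic carbon), and the step is a 1.0-fold higher number from compound 1 to compound 2 (0.02 log units; within the scatter). Compound 3 carries a different group on the amide nitrogen, (2,4-difluorophenyl in place of 4-fluoro-3-methylphenyl on an amide-type nitrogen); the step is a 2.3-fold lower number from compound 1 to compound 3 (0.36 log units; beyond the scatter), and from compound 2 it is a 2.4-fold lower number from compound 2 to compound 3 (0.38 log units; beyond the scatter). Compound 4, `CN1C[C@H](C(=O)Nc2ccc(Cl)cc2F)[C@@H](c2ccc(/C=C/C(=O)Nc3ccccc3N)cc2)C1`, has not yet been measured in this assay. It differs from compound 3 by chloro in place of fluoro on an aromatic carbon. This is the same kind of change as that from compound 1 to compound 2, though the surroundings differ: in compound 1 the exchanged halogen sits ortho to a methyl group, in compound 3 meta to a fluoro group, and in both para to a large group. Because the earlier step was a 1.0-fold higher number from compound 1 to compound 2 (0.02 log units; within the scatter), the step is expected to be a 1.1-fold higher number from compound 3 to compound 4 (0.05 log units; within the scatter). Compound 4 is therefore estimated at 30 mL/min/kg, with a likely range from 15 mL/min/kg to 60 mL/min/kg.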

Compound 4, clearance: 43 mL/min/kg
Compound 4: middle estimate off by 1.4-fold (0.16 log units), on the low side; low and high end bracket the measured number.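

In this assay, chloro in place of fluoro on an aromatic carbon behaved alike on the two cores, as far as these data can tell: the same change on two cores in this assay, a 1.0-fold higher number (0.02 log units; within the scatter) from compound 1 to compound 2 and a 1.6-fold higher number (0.20 log units; within the scatter) from compound 3 to compound 4, 1.5-fold (0.18 log units) apart, within the scatter of two such steps. The new pair gives a 1.6-fold higher number from compound 3 to compound 4 (0.20 log units; within the scatter), so nothing here suggests that the core changes the outcome, but two pairs cannot establish that the change carries over to other cores in the series. The other new steps, a 1.5-fold lower number from compound 2 to compound 4 (0.18 log units; within the scatter) and a 1.4-fold lower number from compound 1 to compound 4 (0.16 log units; within the scatter), also lie within the scatter, so those exchanges of the group on the amide nitrogen show no clear difference.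

The compounds shown leave open how a bromo, methoxy or nitrile group would compare at this place on the ring.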